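From 3-(trifluoromethyl)phenyl to 3,4-dichlorophenyl

The source may hold more compounds than are shown below. What is called first, only, known or untested is meant among the compounds shown, and "the series" means these compounds.

Values measured in an ADME assay on BJ cells (Homo sapiens) for cytotoxicity, read by CellTiter-Glo and resazurin assay, with a stated time of 72 h; a higher number here means that more compound is needed for the effect, a lower number that less compound is needed:
Compound 1 `CC(C)N(Cc1cccc(OCCCCCC(=O)O)c1)C(=O)c1ccc(-c2cccc3ccccc23)cc1`: < 1.3 nM (a limit)
Compound 2 `CC(=O)c1cccc(-c2ccc(C(=O)N(Cc3cccc(OCCCCCC(=O)O)c3)C(C)C)cc2)c1`: > 26000 nM (a limit)
Compound 3 `CC(C)N(Cc1cccc(OCCCCCC(=O)O)c1)C(=O)c1ccc(-c2cccc(C(F)(F)F)c2)cc1`: > 26000 nM (a limit)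

Compound 3 has no exact number in this assay. It stands at the limit of > 26000 nM in this assay, at which 2 of the 3 values shown sit, and compound 2 shares that limit.

Compound 4 `CC(C)N(Cc1cccc(OCCCCCC(=O)O)c1)C(=O)c1ccc(-c2ccc(Cl)c(Cl)c2)cc1` has not yet been measured. The change from its neighbour is 3,4-dichlorophenyl in place of 3-(trifluoromethyl)phenyl on an aromatic carbon: 3,4-dichlorophenyl in place of 3-(trifluoromethyl)phenyl, on an aromatic carbon para to a large group.

Within the data shown here, three measured steps concern this same place. Two are large and lie beyond the scatter: an at least 20000-fold higher number from compound 1 to compound 2 (4.30 log units; beyond the scatter) and an at least 20000-fold higher number from compound 1 to compound 3 (4.30 log units; beyond the scatter). Both of them, however, start from naphthalen-1-yl, which compound 4 does not carry. The closest comparison is a step that the two limits leave unreadable from compound 2 to compound 3, a swap between two substituted phenyl groups, and its two limits hide any real size.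

Compound 4 also keeps a substituted phenyl there, so, going by an at least 20000-fold higher number from compound 1 to compound 3 (4.30 log units; beyond the scatter), it is expected to remain with compound 2 and compound 3 rather than move toward compound 1. No step beyond the scatter is expected, and the assay may well report only a limit again. The expected change is a number no higher from compound 3 to compound 4 (the limit leaves the size open). For compound 4 the estimated value is 26000 nM, with an expected range from 4000 nM to 60000 nM.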

Compound 4, half-maximal effective concentration: > 26000 nM
Compound 4: no number, only a limit; the forecaster's own chance of this, stated with the estimate: 75%; the middle value lies on the limit itself.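

In this assay compound 4 gives > 26000 nM, which is a limit of the assay and not a number. A third substituted phenyl at this place, 3,4-dichlorophenyl with its two chlorine atoms, thus joins 3-acetylphenyl and 3-(trifluoromethyl)phenyl at the same upper limit, and the steps among these three compounds cannot be read: the limit of > 26000 nM in this assay, at which 3 of the 4 values shown sit. The large gap to the naphthalen-1-yl group now holds for a third replacement, an at least 20000-fold higher number from compound 1 to compound 4 (4.30 log units; beyond the scatter), so among the compounds shown it does not rest on a single phenyl substituent.

As far as these compounds go, how far compound 2, compound 3 and compound 4 each lie past their shared limit remains unknown, so no order among them can be drawn from these values. Also open, from the compounds shown here alone, is which feature of naphthalen-1-yl goes with the low value, and whether naphthalen-2-yl, unsubstituted phenyl or a phenyl carrying an amine at this place would stay at the upper limit or move toward compound 1.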